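The compounds below may be only part of what the source reports. "The series", "measured", "known", "first", "only" and "open" are said of these compounds alone.

In a functional assay on U-251 cells (Homo sapiens) (a higher number here means a weaker inhibitor of growth, a lower number a stronger inhibitor of growth), compound 1 `O=S(=O)(/C=C/c1ccc(Cl)c(Cl)c1)Cc1ccc(Nc2ncnc3ccccc23)cc1` gives 11000 nM and compound 2 `O=S(=O)(/C=C/c1ccc(Cl)cc1Cl)Cc1ccc(Nc2ncnc3ccccc23)cc1` gives 4000 nM. Compound 3 `O=S(=O)(/C=C/c1ccc(Cl)c(Cl)c1)Cc1ccc(Nc2ncnc3ccc(Br)cc23)cc1` stands at > 100000 nM, which is a limit of the assay and not a number. Compound 4 `O=S(=O)(/C=C/c1ccc(O)cc1)Cc1ccc(Nc2ncnc3ccc(Br)cc23)cc1` keeps the bromo of compound 3 and differs from it by 4-hydroxyphenyl in place of 3,4-dichlorophenyl on a double-bonded chain carbon bound to a double-bonded chain carbon, with 4-hydroxyphenyl in place of 3,4-dichlorophenyl. Going by the values given here, two measured steps bear on this. Among the compounds with values here, the only change to the aryl group so far, a 2.8-fold lower number from compound 1 to compound 2 (0.44 log units; beyond the scatter), was modest, and the bromo step, an at least 9.0-fold higher number from compound 1 to compound 3 (0.95 log units; beyond the scatter), was at least modest and is not undone here. The expected move is modest and toward a lower number, an estimated at least 2.8-fold lower number from compound 3 to compound 4 (0.45 log units; beyond the scatter). Compound 4 is estimated at 35000 nM, with an expected range of 8000 nM to 100000 nM.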

Compound 4, concentration for 50% growth inhibition: > 100000 nM
Compound 4 gave a limit, no number (the forecaster's own chance of this, stated with the estimate: 35%); at least 2.8-fold (0.45 log units) between middle value and limit.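

Going by these compounds alone, compound 3 and compound 4 both end at a limit of the assay, so no step between them can be read: the limit of > 100000 nM in this assay, at which 2 of the 4 values shown sit. The compounds shown leave open whether 4-hydroxyphenyl in place of 3,4-dichlorophenyl moves growth inhibition at all while the bromo stays.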